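From phenoxy to 4-methylphenoxy in compound 3

This account rests on a few compounds, and the source may have more. Where it says the series, first, only, none or still open, it means among the compounds named here.

Compound 1 `Cc1ccc(-c2cnc(N(Cc3ccc(C(=O)NO)cc3)CC(C)C)s2)cc1`: 20400 nM
Compound 2 `CCN(Cc1ccc(C(=O)NO)cc1)c1ncc(-c2ccc(C)cc2)s1`: 2700 nM
Compound 3 `Cc1ccc(-c2cnc(N(CCCCOc3ccccc3)Cc3ccc(C(=O)NO)cc3)s2)cc1`: 14200 nM

In a functional assay on A549 cells (Homo sapiens) for antiproliferative activity, read by MTT assay, with a stated time of 48 h (on this read-out higher numbers stand for weaker inhibition of growth and lower numbers for stronger inhibition of growth), compound 3 gives 14200 nM. That value sits level with one neighbour and clearly apart from the other: the data show a 1.4-fold lower number from compound 1 to compound 3 (0.16 log units; within the scatter), and a 5.3-fold higher number from compound 2 to compound 3 (0.72 log units; beyond the scatter).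

Compound 4 `Cc1ccc(OCCCCN(Cc2ccc(C(=O)NO)cc2)c2ncc(-c3ccc(C)cc3)s2)cc1` carries one change, methyl in place of hydrogen on an aromatic carbon, turning phenoxy into 4-methylphenoxy. Going by the values given here, no measured step tests such a change. The nearest guide is the swap of whole chains, which gave a 7.6-fold lower number from compound 1 to compound 2 (0.88 log units; beyond the scatter) but also a 1.4-fold lower number from compound 1 to compound 3 (0.16 log units; within the scatter). A change this small is therefore expected to stay within the scatter in this assay.

The expected step is a 1.0-fold lower number from compound 3 to compound 4 (0.01 log units; within the scatter).

For compound 4 the estimated value is 14000 nM, with an expected range of 6000 nM to 30000 nM.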

Compound 4, concentration for 50% growth inhibition: 8630 nM
Estimate against measurement, compound 4: 1.6-fold (0.21 log units) above; measured number inside the range.
By their numbers in this assay, from the lowest: compound 2; then compounds 4, 3 and 1 (each within the scatter of the next, the first and the last beyond it).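

Methyl in place of hydrogen on this aromatic carbon is tolerated in this assay, with no change that stands out from the scatter (a step of a 1.6-fold lower number from compound 3 to compound 4 (0.22 log units; within the scatter)). The long chain still gives weaker growth inhibition than the short chain (a step of a 3.2-fold higher number from compound 2 to compound 4 (0.50 log units; beyond the scatter)), while the gap to the isopropyl-bearing chain now lies just beyond the scatter (a step of a 2.4-fold lower number from compound 1 to compound 4 (0.37 log units; beyond the scatter)). No evidence here accounts for these numbers.

As far as these compounds go, whether methoxy or chlorine in the same place would shift the number remains open. So does whether an amine at the chain end would close the gap to compound 2.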